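The source may hold more compounds than are shown below. What is called first, only, known or untested is meant among the compounds shown, and "the series" means these compounds.

Compound 1 `COc1ccc(OC)c(/C=N/c2c(C#N)ncn2-c2ccc(F)cc2)c1` is tested in a functional assay on MDA-MB-231 cells (Homo sapiens) for antiproliferative activity, read by MTT assay, with a stated time of 48 h (a higher number here means a weaker inhibitor, a lower number a stronger inhibitor), where compound 1 gives 12300 nM. Compound 2 `COc1cc(/C=N/c2c(C#N)ncn2-c2ccc(F)cc2)ccc1O` shares a core with compound 1, but the difference between the two cores is not broken down here; in this assay compound 2 gives 13600 nM. Compound 3 `COc1ccc(OC)c(/C=N/c2c(C#N)ncn2Cc2ccc(F)cc2)c1` carries 4-fluorobenzyl in place of 4-fluorophenyl on an aromatic nitrogen, and in this assay compound 3 gives 17600 nM, a step of a 1.4-fold higher number from compound 1 to compound 3 (0.16 log units; within the scatter). Compound 4 `COc1cc(/C=N/c2c(C#N)ncn2Cc2ccc(F)cc2)ccc1O` carries the same change on the core of compound 2, namely (4-fluorobenzyl in place of 4-fluorophenyl on an aromatic nitrogen). Because the change from compound 1 to compound 3 moved the number by a 1.4-fold higher number from compound 1 to compound 3 (0.16 log units; within the scatter), a step of similar size is expected from compound 2 to compound 4, namely a 1.3-fold higher number from compound 2 to compound 4 (0.12 log units; within the scatter). Compound 4 is therefore estimated at 18000 nM, with a likely range from 9000 nM to 36000 nM.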

Compound 4, half-maximal inhibitory concentration: 16100 nM
Estimate against measurement, compound 4: 1.1-fold (0.05 log units) above, within the range that was stated.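

In this assay, 4-fluorobenzyl in place of 4-fluorophenyl on an aromatic nitrogen gives a step of a 1.2-fold higher number from compound 2 to compound 4 (0.07 log units; within the scatter). Set beside the earlier step, the change carries from one core to the other without a difference that can be told apart: the same change on two cores in this assay, a 1.4-fold higher number (0.16 log units; within the scatter) from compound 1 to compound 3 and a 1.2-fold higher number (0.07 log units; within the scatter) from compound 2 to compound 4, 1.2-fold (0.08 log units) apart, within the scatter of two such steps. This does not show that the change itself moves the number on either core, and two cores cannot speak for the whole series.

The compounds shown leave open whether a longer chain on that nitrogen, such as a 2-(4-fluorophenyl)ethyl group, would give a step beyond the scatter. They also leave open what a carboxylic acid or an amine in place of the fluorine would do.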